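Piperazine nitrogen substitution in the amide series

This account rests on a few compounds, and the source may have more. Where it says the series, first, only, none or still open, it means among the compounds named here.

Three compounds of the series carry a measurement in a functional assay on MCF7 cells (Homo sapiens) for cytotoxicity, read by MTT assay, with a stated time of 24 h, tested at 6.4 ug/mL; on this read-out higher numbers stand for a stronger effect at the one concentration tested and lower numbers for a weaker effect. Compound 1 `Cn1c(-c2ccc(NC(=O)CCl)cc2)nc(-c2ccccc2)c1-c1ccccc1` gives 14.2%, compound 2 `CCN1CCN(CC(=O)Nc2ccc(-c3nc(-c4ccccc4)c(-c4ccccc4)n3C)cc2)CC1` gives 16.4%, and compound 3 `CN(C)/C=C/N1CCN(CC(=O)Nc2ccc(-c3nc(-c4ccccc4)c(-c4ccccc4)n3C)cc2)CC1` gives 11.1%. Compound 3 holds the lowest of the three numbers, but every step to it falls within the scatter: a number 3.1 percentage points lower from compound 1 to compound 3 (within the scatter) and a number 5.3 percentage points lower from compound 2 to compound 3 (within the scatter), as does the step of a number 2.2 percentage points higher from compound 1 to compound 2 (within the scatter). No order among the three can therefore be claimed.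

Compound 4 `COc1ccc(CN2CCN(CC(=O)Nc3ccc(-c4nc(-c5ccccc5)c(-c5ccccc5)n4C)cc3)CC2)cc1` is not yet measured. It differs from compound 3 by 4-methoxybenzyl in place of 2-(dimethylamino)ethenyl on an amine nitrogen in a ring. The step that bears most directly on this change is a number 5.3 percentage points lower from compound 2 to compound 3 (within the scatter), since it also varies the substituent on the ring amine nitrogen. The two replacements of chloro by a piperazinyl group, a number 2.2 percentage points higher from compound 1 to compound 2 (within the scatter) and a number 3.1 percentage points lower from compound 1 to compound 3 (within the scatter), were likewise within the scatter. No step beyond the scatter is therefore expected in this assay , in either direction. Compound 4 is estimated at 14%, with a range from 5% to 25%. The estimated step is accordingly a number 2.9 percentage points higher from compound 3 to compound 4 (within the scatter), inside the usual scatter.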

Compound 4, a percentage reported as activity, at one concentration (the size of the read-out at that concentration, not a potency): 29%
For compound 4 the middle estimate is 15 percentage points below the measured one, and the stated range ends below it.
By their numbers in this assay, from the lowest: compounds 3, 1 and 2 (each within the scatter of the next); then compound 4.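

In this assay the amine nitrogen in the ring now proves able to carry a step beyond the scatter, a number 17.9 percentage points higher from compound 3 to compound 4 (beyond the scatter) and a number 12.6 percentage points higher from compound 2 to compound 4 (beyond the scatter), whereas ethyl and 2-(dimethylamino)ethenyl on that nitrogen stayed within the scatter of each other. Among these three substituents, only 4-methoxybenzyl brings a six-membered aromatic ring of carbon only, but this rests on compound 4 alone and is no established pattern. Nothing at hand gives a reason for these steps.

The compounds shown do not separate the part played by the methoxy group from that of the aromatic ring, nor that of the link to the nitrogen; plain benzyl or 2-phenylethyl on the same nitrogen would address this. Going by these compounds, whether the steps hold at other concentrations also remains open.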